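The source may hold more compounds than are shown below. What is called first, only, known or untested is meant among the compounds shown, and "the series" means these compounds.

Measured in a functional assay on A549 cells (Homo sapiens) for cytotoxicity, read by MTT assay, with a stated time of 72 h; on this read-out lower numbers stand for stronger inhibition and higher numbers for weaker inhibition:
- compound 1 `CC1CCN(Cc2ccc3nc(NC(=O)N/N=C/c4c[nH]c5ccccc45)sc3c2)CC1`: 3580 nM
- compound 2 `CN(C)Cc1ccc2nc(NC(=O)N/N=C/c3c[nH]c4ccccc34)sc2c1`: 3300 nM

Compound 2 stands at 3300 nM, level with compound 1 within the usual scatter. Compound 3 `CN(C)Cc1ccc2nc(NC(=O)N/N=C/c3cn(Cc4ccc(Cl)cc4)c4ccccc34)sc2c1` carries 4-chlorobenzyl in place of hydrogen on an aromatic nitrogen. Going by the values given here, the only measured step, a 1.1-fold lower number from compound 1 to compound 2 (0.04 log units; within the scatter), lies at a different place in the molecule, so it sets no size for this change. No change at this nitrogen has been measured, so the direction is a judgement: with so sizeable a group entering, a lower number seems more likely than no change. The expected move is a 4.7-fold lower number from compound 2 to compound 3 (0.67 log units; beyond the scatter). For compound 3 the estimate is 700 nM, with an expected range of 150 nM to 3000 nM.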

Compound 3, half-maximal inhibitory concentration: 840 nM
Compound 3: middle estimate off by 1.2-fold (0.08 log units), on the low side; the measured number falls inside the stated range.
By their numbers in this assay, from the lowest: compound 3; then compounds 2 and 1 (each within the scatter of the next).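

In this assay, going by these compounds alone, 4-chlorobenzyl in place of hydrogen on the aromatic nitrogen gives a 3.9-fold lower number from compound 2 to compound 3 (0.59 log units; beyond the scatter), the first step in this set beyond the usual scatter. Within the data shown here, the earlier pair differed at another place, so this is the first sign that changing this nitrogen can move the number, and here a group of this size lowers it.

Going by these compounds, whether plain benzyl, methyl or a longer chain bearing an amine on this nitrogen would do the same stays open. Nothing measured here gives a reason for the step.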